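The source may hold more compounds than are shown below. What is called first, only, known or untested is meant among the compounds shown, and "the series" means these compounds.

Of the compounds shown here, two of one macrolide series have been measured so far. Compound 1 `CCC(=O)NCCCO[C@H]1[C@H](C)[C@@H](O[C@@H]2O[C@H](C)C[C@H](N(C)C)[C@H]2O)[C@](C)(O)C[C@@H](C)CN(C)[C@H](C)[C@@H](O)[C@](C)(O)[C@@H](CC)OC(=O)[C@@H]1C` and compound 2 `CC[C@H]1OC(=O)[C@H](C)[C@@H](O[C@H]2C[C@@](C)(OC)[C@@H](OCCCNC(=O)COC)[C@H](C)O2)[C@H](C)[C@@H](O[C@@H]2O[C@H](C)C[C@H](N(C)C)[C@H]2O)[C@](C)(O)C[C@@H](C)CN(C)[C@H](C)[C@@H](O)[C@]1(C)O` were both run in a physicochemical assay for lipophilicity, read by HPLC, measured as chromatographic lipophilicity, at pH 7.4; a higher number here means a more lipophilic compound, a lower number a more polar compound. In this assay compound 1 gives 1.6, and compound 2 gives 2.16; compound 1 therefore holds the lower of the two numbers, and the gap to compound 2 lies beyond the usual scatter of repeated measurements.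

Compound 3 `CC[C@H]1OC(=O)[C@H](C)[C@@H](O)[C@H](C)[C@@H](O[C@@H]2O[C@H](C)C[C@H](N(C)C)[C@H]2O)[C@](C)(O)C[C@@H](C)CN(C)[C@H](C)[C@@H](O)[C@]1(C)O` has not yet been measured. It differs from compound 1 in one place: hydrogen in place of 3-(propanoylamino)propyl on an oxygen on a saturated carbon, so that the side chain is cut away and only the hydroxy group remains on the shared core. Within the data shown here, no measured pair in this set shows this same change, so its effect on this assay can only be guessed. The step from compound 1 to compound 3 is expected to be a modest decrease, a number 0.50 log units lower from compound 1 to compound 3 (beyond the scatter), with nothing in the measured numbers to rule out no change at all. On that basis compound 3 is estimated at 1.1 in this assay, with a likely range from 0.5 to 1.7.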

Compound 3, distribution coefficient: 1.35
For compound 3 the middle estimate is 0.25 log units below the measured one, and the stated range covers the measured number.
By their numbers in this assay, from the lowest: compounds 3 and 1 (each within the scatter of the next); then compound 2.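

Among these compounds, this is the first measured pair at this position, an oxygen on a saturated carbon. In this assay, hydrogen in place of 3-(propanoylamino)propyl gives a number 0.25 log units lower from compound 1 to compound 3 (within the scatter) and so leaves compound 1 and compound 3 indistinguishable, even though the chain that leaves has 8 heavy atoms. Nothing available accounts for this result.

Going by these compounds, it remains open whether other groups on this oxygen, such as a plain propyl chain, a longer chain, or a chain ending in an amine or a carboxylic acid, would also stay within the scatter of compound 3. Compound 2 differs from compound 1 in more than one place, so its number cannot isolate the effect of this change.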